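Isobutylamino for piperazinyl on the shared bicyclic core

A few compounds are considered here, and "the series" means these few. Any claim that something is new, unique, unknown or untested is made for them only; others in the source may bear on it.

Compound 1 `FC(F)(F)c1ccc(Nc2ncnc3sc(Nc4ccccc4Cl)nc23)cc1` and compound 2 `Cc1ccc(Nc2ncnc3sc(Nc4c(Cl)cccc4Cl)nc23)cc1` carry hydrogen at the carbon that compound 3 `FC(F)(F)c1ccc(Nc2nc(N3CCNCC3)nc3sc(Nc4c(Cl)cccc4Cl)nc23)cc1` substitutes with piperazin-1-yl. In a functional assay on HEK293 cells for antagonist activity at transient receptor potential cation channel subfamily V member 1 (Rattus norvegicus), read by calcium flux (a lower number here means a stronger inhibitor, a higher number a weaker inhibitor), compound 1 gives 32 nM, and compound 2 gives 32 nM; the two values sit within the usual scatter of one another. Compound 3 stands apart: in this assay it reaches only the limit of the measurement, reported as > 5000 nM, so no number is known for it. Of the three values shown, this is the one that sits at the limit of > 5000 nM in this assay, at which 1 of the 3 values shown sits.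

Compound 4 `CC(C)CNc1nc(Nc2ccc(C(F)(F)F)cc2)c2nc(Nc3c(Cl)cccc3Cl)sc2n1` follows from compound 3 by a single change, (isobutylamino in place of piperazin-1-yl on an aromatic carbon), that is, isobutylamino in place of piperazin-1-yl on an aromatic carbon between two ring nitrogen atoms, meta to the (4-(trifluoromethyl)phenyl)amino group, meta to a fused ring and para to a fused ring. Among the measured compounds shown here, no measured pair maps this exchange, and compound 3 offers only a limit, so the size of the step is open. The working expectation is that compound 4 returns into the measurable range, an estimated step of an at least 6.2-fold lower number from compound 3 to compound 4 (0.79 log units; beyond the scatter) toward stronger inhibition, though it may also remain at the limit. Compound 4 is thus estimated in this assay at 800 nM, with a range from 80 nM to 8000 nM.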

Compound 4, half-maximal inhibitory concentration: 1 nM
Compound 4: the middle estimate sits 800-fold (2.90 log units) above what was measured, and the stated range ends above it.
By their numbers in this assay, from the lowest: compound 4; then compounds 1 and 2 (each within the scatter of the next). At a limit, above all of these: compound 3.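

In this assay, isobutylamino in place of piperazin-1-yl on the aromatic carbon between two ring nitrogen atoms gives an at least 5000-fold lower number from compound 3 to compound 4 (3.69 log units; beyond the scatter), so this single exchange decides between no measurable inhibition and very strong inhibition. On these data alone, the step counts from a limit for compound 3 and not from a number, so its true size stays open: the limit of > 5000 nM in this assay, at which 1 of the 4 values shown sits. With compound 4 at 1 nM, a substituent on this carbon is clearly compatible with strong inhibition.

The exchange removes a ring and a nitrogen together, so the compounds shown cannot say which of these differences matters; a straight butylamino chain, a cyclohexylamino group or a morpholin-4-yl ring at this carbon would begin to separate them. No compound shown pairs hydrogen at this carbon with the remainder of compound 4, so the contribution of isobutylamino relative to the unsubstituted carbon also remains open.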